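The compounds below may be only part of what the source reports. "The series", "measured", "known", "first", "only" and "open" are said of these compounds alone.

Values so far in a functional assay on K562/A02 cells (Homo sapiens) for antiproliferative activity, read by MTT assay; a higher number here means a weaker inhibitor, a lower number a stronger inhibitor

- Compound 1 `O=C(CCCCCNC(=S)N/N=C(\c1ccccc1)c1ccccn1)NO` gives 2030 nM
- Compound 2 `O=C(CCCCCNC(=S)N/N=C(\c1ccccc1)c1ccccc1F)NO` gives 6010 nM
- Compound 3 `O=C(CCCCCNC(=S)N/N=C(\c1ccccc1)c1cccc([N+](=O)[O-])c1)NO` gives 940 nM

Compound 3 has the lowest number of the three, which makes it the strongest inhibitor so far. Compound 4 `COc1ccccc1/C(=N/NC(=S)NCCCCCC(=O)NO)c1ccccc1` differs from it as follows: 2-methoxyphenyl in place of 3-nitrophenyl on a carbon with a double bond to nitrogen, with 2-methoxyphenyl in place of 3-nitrophenyl on a carbon with a double bond to nitrogen. Among the compounds with values here, no 2-methoxyphenyl compound has been measured yet, so only the neighbouring changes can guide the estimate. The largest is a 6.4-fold lower number from compound 2 to compound 3 (0.81 log units; beyond the scatter), and the other is a 2.2-fold lower number from compound 1 to compound 3 (0.33 log units; beyond the scatter). Both show 3-nitrophenyl with the lower number, so losing it should raise the number by a modest step. The estimate is a 3.2-fold higher number from compound 3 to compound 4 (0.50 log units; beyond the scatter). For compound 4 the expected value is 3000 nM, with an estimated range of 1100 nM to 8000 nM.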

Compound 4, half-maximal inhibitory concentration: 2910 nM
Estimate against measurement, compound 4: 1.0-fold (0.01 log units) above; measured number inside the range.
By their numbers in this assay, from the lowest: compound 3; then compounds 1 and 4 (each within the scatter of the next); then compound 2.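

At this carbon in this assay, 2-methoxyphenyl in place of 3-nitrophenyl gives a 3.1-fold higher number from compound 3 to compound 4 (0.49 log units; beyond the scatter) and methoxy in place of fluoro on an aromatic carbon gives a 2.1-fold lower number from compound 2 to compound 4 (0.31 log units; beyond the scatter), so a second group on the ring can leave the number well apart from both neighbours. Against pyridin-2-yl, the change gives a 1.4-fold higher number from compound 1 to compound 4 (0.16 log units; within the scatter), so compound 1 and compound 4 cannot be told apart. Nothing measured here gives a reason for these differences. From the compounds shown here alone, how an amine or a carboxylic acid on that aromatic ring would compare remains open.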